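This account rests on a few compounds, and the source may have more. Where it says the series, first, only, none or still open, it means among the compounds named here.

Three compounds of this study share one core, and all three come to the same stop in an assay for inhibition of Fatty-acid amide hydrolase 1 (Rattus norvegicus); a lower number here means a stronger inhibitor, a higher number a weaker inhibitor. Compound 1 `CC(=O)Cn1nnnc1Cc1ccc(-c2ccccc2)cc1` gives in this assay > 50000 nM, which is a limit rather than a number. Compound 2 `CN(C)C(=O)Cn1nnc(CNC(=O)c2ccc(-c3ccccc3)cc2)n1` gives in this assay > 50000 nM, again a limit. Compound 3 `CC(=O)Cn1nnc(CNC(=O)c2ccc(-c3ccccc3)cc2)n1` gives in this assay > 50000 nM, also a limit. For the measured compounds named here, the one step between measured compounds, a step that the two limits leave unreadable from compound 2 to compound 3, cannot be sized, and all three values rest at the limit of > 50000 nM in this assay, at which 3 of the 3 values shown sit. Compound 3 thus stands exactly where the other two stand, with no number of its own. Compound 4 `COC(=O)Cn1nnc(CNC(=O)c2ccc(-c3ccccc3)cc2)n1` alters compound 3 in a single place: methoxy in place of methyl on a carbonyl carbon. Going by the values given here, no measured step bears on this exchange; the only measured step is unreadable. With nothing to point toward a different outcome, compound 4 is expected to stay at the limit, and the expected step of a number no higher from compound 3 to compound 4 (the limit leaves the size open) is none beyond the scatter. Compound 4 is therefore estimated at 50000 nM, within a range from 20000 nM to 150000 nM.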

Compound 4, half-maximal inhibitory concentration: > 50000 nM
Compound 4 was reported as a limit (the forecaster's own chance of this, stated with the estimate: 80%); the middle value sits exactly at the limit.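

In this assay compound 4 gives > 50000 nM, which is a limit. The steps to compound 4 from compound 2 and compound 3 cannot be read, and all the values rest at one stop: the limit of > 50000 nM in this assay, at which 4 of the 4 values shown sit. The compounds shown leave open whether any change on the shared core would give a readable number.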